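Working notes: amine and azide nucleoside analogues, inhibition

This account rests on a few compounds, and the source may have more. Where it says the series, first, only, none or still open, it means among the compounds named here.

Measured so far:
compound 1 `OC[C@H]1OC(n2cnc3c(NCc4ccccc4)nccc32)[C@H](O)[C@@H]1O`: 5%
compound 2 `[N-]=[N+]=Nc1nccc2c1ncn2C1O[C@H](CO)[C@@H](O)[C@H]1O`: < 5%

In a functional assay on EL4 cells (Mus musculus) for inhibition, tested at 100 uM (on this read-out higher numbers stand for more inhibition at the one concentration tested (going by the name of the read-out) and lower numbers for less inhibition), compound 1 gives 5%. For compound 2 the reading is only a limit of the assay, not a number, and compound 2 stands at the limit of < 5% in this assay, at which 1 of the 2 values shown sits. Going by the values given here, the one measured step is a number no higher from compound 1 to compound 2 (the limit leaves the size open). Compound 3 `CCCCCCNc1nccc2c1ncn2C1O[C@H](CO)[C@@H](O)[C@H]1O` differs from compound 2 by hexylamino in place of azido on an aromatic carbon. Among the compounds with values here, only that step bears on this change, and with a limit at one end it gives no readable size, so no step beyond the scatter is expected. Compound 3 is expected near 5%, within 0% to 15%. The expected step is a number no lower from compound 2 to compound 3 (the limit leaves the size open).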

Compound 3, a percentage reported as inhibition, at one concentration (the size of the read-out at that concentration, not a potency): 14%
Compound 3: middle estimate off by 9 percentage points, on the low side; low and high end bracket the measured number.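

With hexylamino on this aromatic carbon next to the ring nitrogen, the change in this assay reads as a number at least 9 percentage points higher from compound 2 to compound 3 (that floor lies within the scatter), so this position accepts the chain but shows no step beyond the scatter. Pentyl in place of phenyl on the chain carbon bound to the nitrogen gives a number 9 percentage points higher from compound 1 to compound 3 (within the scatter), so the two amine side chains are not told apart at this one concentration. Compound 2 stays a limit of the assay, not a number: the limit of < 5% in this assay, at which 1 of the 3 values shown sits.

Still open, on these data alone, is whether a longer chain than hexylamino, or a carboxylic acid at the chain end, gives a step beyond the scatter.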